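Compound 3 to compound 4: exchanging the amide substituent

This account rests on a few compounds, and the source may have more. Where it says the series, first, only, none or still open, it means among the compounds named here.

Measured in a functional assay on SW480 cells (Homo sapiens) for cytotoxicity, read by MTT assay, with a stated time of 48 h; on this read-out higher numbers stand for weaker inhibition and lower numbers for stronger inhibition:
Compound 1 `CCOC(=O)[C@@]1(C(=O)NCc2ccc(C)cc2)C[C@H]1c1cc(OC)c(OC)c(OC)c1`: > 100000 nM (a limit)
Compound 2 `CCOC(=O)[C@]1(C(=O)NCc2ccc(C)cc2)C[C@H]1c1cc(OC)c(OC)c(OC)c1`: 36400 nM
Compound 3 `CCOC(=O)[C@]1(C(=O)Nc2ccccc2Cl)C[C@@H]1c1cc(OC)c(OC)c(OC)c1`: > 100000 nM (a limit)

Compound 3 gives no number in this assay, only the limit > 100000 nM. Compound 4 (`CCOC(=O)[C@]1(C(=O)NCc2ccc(C)cc2)C[C@@H]1c1cc(OC)c(OC)c(OC)c1`) differs from it as follows: 4-methylbenzyl in place of 2-chlorophenyl on an amide-type nitrogen. Among the measured compounds shown here, no measured step covers this exchange directly. The nearest evidence is an at least 2.7-fold lower number from compound 1 to compound 2 (0.43 log units; beyond the scatter), which goes with the fact that compounds 1 and 2 differ only in the configuration as drawn. Both of those compounds carry 4-methylbenzyl, so that group alone does not settle the value. A modest step towards a lower number is expected, since compound 2 reaches 36400 nM. The estimated change is an at least 1.4-fold lower number from compound 3 to compound 4 (0.15 log units; that floor lies within the scatter). For compound 4 the estimated value is 70000 nM, with an expected range of 25000 nM to 150000 nM.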

Compound 4, half-maximal inhibitory concentration: > 100000 nM
Compound 4 was reported as a limit (the forecaster's own chance of this, stated with the estimate: 45%); at least 1.4-fold (0.15 log units) between middle value and limit.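

Among the 4-methylbenzyl amides in this assay, inverting a single stereocentre gives an at least 2.7-fold higher number from compound 2 to compound 4 (0.43 log units; beyond the scatter). Configuration therefore separates these two compounds, while the 4-methylbenzyl group alone gives no measurable value, and the change is confined to one saturated ring carbon: the fact that compounds 2 and 4 differ only in the configuration as drawn. The steps to compound 4 from compound 3 and from compound 1 cannot be read, as each joins two limits.

On these data alone, whether 2-chlorophenyl gives a number in the configuration of compound 2 remains open. So does the effect of a carboxylic acid or an aminoethyl chain on the amide nitrogen.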